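From ethoxy to pyridin-4-yl on the shared core

The source may hold more compounds than are shown below. What is called first, only, known or untested is meant among the compounds shown, and "the series" means these compounds.

In a functional assay on THP-1 cells (Homo sapiens) for inhibition, read by sulforhodamine B assay, with a stated time of 48 h (a higher number here means a weaker inhibitor, a lower number a stronger inhibitor), compound 1 `CCO[C@H]1C[C@@H](c2coc3ccccc3c2=O)N(c2ccccc2)O1` reaches only a limit, > 60000 nM. Compound 2 `CCO[C@H]1C[C@@H](c2coc3ccc(F)cc3c2=O)N(c2ccccc2)O1` also reaches only a limit, > 60000 nM. Compound 3 `CCO[C@H]1C[C@@H](c2coc3ccc(C)cc3c2=O)N(c2ccccc2)O1` gives a number, 41000 nM.

Compound 4 `O=c1c([C@@H]2C[C@H](c3ccncc3)ON2c2ccccc2)coc2ccccc12` carries pyridin-4-yl in place of ethoxy on a saturated ring carbon. The measured steps lie elsewhere, on an aromatic carbon: a step that the two limits leave unreadable from compound 1 to compound 2, and an at least 1.4-fold lower number from compound 1 to compound 3 (0.16 log units; that floor lies within the scatter). Neither sizes this change, so little or no step beyond the scatter is expected, with any shift leaning towards a lower number. The estimated change is an at least 1.3-fold lower number from compound 1 to compound 4 (0.12 log units; that floor lies within the scatter). For compound 4 the expected value in this assay is 45000 nM, within an estimated range from 15000 nM to 90000 nM.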

Compound 4, half-maximal inhibitory concentration: 16400 nM
The estimate for compound 4 lay 2.7-fold (0.44 log units) above the measured number; the range from low to high includes it.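

In this assay, the saturated ring carbon next to the ring oxygen responds to substitution: pyridin-4-yl in place of ethoxy gives an at least 3.6-fold lower number from compound 1 to compound 4 (0.56 log units; beyond the scatter). The earlier steps shown here, all on an aromatic carbon, showed nothing beyond the scatter. This step is only a floor because compound 1 stands at a limit of the assay: the limit of > 60000 nM in this assay, at which 2 of the 4 values shown sit.

Going by these compounds, it remains open whether an amine, a carboxylic acid or a longer chain at this carbon would compare with pyridin-4-yl. On these data alone, whether methyl on the aromatic carbon would add to this change also remains open.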